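Replacing the Aminoethyl Amide of Compound 2 with Nitriles

The source may report more compounds than this note shows. Statements on the series, on what has been measured and on what is new or still open speak of the compounds shown alone.

Measured so far:
compound 1 `CCOC(=O)CN(C)C(=O)c1ccc(C(CC)(CC)c2ccc(OCC(O)C(C)(C)C)c(C)c2)n1CC` 10100 nM
compound 2 `CCN(CC)CCNC(=O)c1ccc(C(CC)(CC)c2ccc(OCC(O)C(C)(C)C)c(C)c2)n1CC` 2500 nM
compound 3 `CCn1c(C(=O)NCCN)ccc1C(CC)(CC)c1ccc(OCC(O)C(C)(C)C)c(C)c1` 2400 nM

In an ADME assay on L02 cells (Homo sapiens) for cytotoxicity, read by MTT assay, with a stated time of 48 h (on this read-out higher numbers stand for weaker inhibition and lower numbers for stronger inhibition), compound 2 stands second highest of the three numbers; compound 3 sits within the scatter of it, while compound 1 is well apart: a 4.0-fold lower number from compound 1 to compound 2 (0.61 log units; beyond the scatter). The step to compound 4 `CCn1c(C(=O)N(CCC#N)CCC#N)ccc1C(CC)(CC)c1ccc(OCC(O)C(C)(C)C)c(C)c1` makes this change: a group of 9 heavy atoms (6 carbon, 3 nitrogen; no ring) in place of a group of 8 heavy atoms (6 carbon, 2 nitrogen; no ring), on a carbonyl carbon. Going by the values given here, two measured steps bear on it. The step of a 1.0-fold lower number from compound 2 to compound 3 (0.02 log units; within the scatter) shows that swapping one amine-bearing chain for another changes nothing. The step of a 4.0-fold lower number from compound 1 to compound 2 (0.61 log units; beyond the scatter) shows that leaving the amide without such a chain, as in compound 1, goes with a higher number. Compound 4 has no such chain, so a modest rise is expected, a 2.4-fold higher number from compound 2 to compound 4 (0.38 log units; beyond the scatter). Compound 4 is therefore estimated at 6000 nM, with a range of 2500 nM to 15000 nM.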

Compound 4, half-maximal inhibitory concentration: 1700 nM
Compound 4: the middle estimate sits 3.5-fold (0.55 log units) above what was measured, outside the stated range (below it).
By their numbers in this assay, from the lowest: compounds 4, 3 and 2 (each within the scatter of the next); then compound 1.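

In this assay, an amine-bearing chain on this carbonyl carbon turns out not to be needed: the nitrile-bearing group of compound 4 gives a 1.5-fold lower number from compound 2 to compound 4 (0.17 log units; within the scatter) and a 1.4-fold lower number from compound 3 to compound 4 (0.15 log units; within the scatter), both within the scatter. The separation that remains is a 5.9-fold lower number from compound 1 to compound 4 (0.77 log units; beyond the scatter), so among these four compounds only the ((ethoxycarbonyl)methyl)(methyl)amino group goes with a higher number. No measurement shown explains this. Still open, going by these compounds, is whether a carboxylic acid in place of that ester would also stand apart, and whether a longer chain ending in nitrile would stay level with compound 4.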